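Series notes: aryl ether pair with a chain variation

This account rests on a few compounds, and the source may have more. Where it says the series, first, only, none or still open, it means among the compounds named here.

Measured so far:
compound 1 `CCC(CC)Oc1cc(C)nc(Oc2c(C)cc(OC)cc2C)c1C` — 75%
compound 2 `CCOc1cc(C)c(Oc2nc(C)cc(OC(CC)CC)c2C)c(C)c1` — 43%

Compound 1 `CCC(CC)Oc1cc(C)nc(Oc2c(C)cc(OC)cc2C)c1C` and compound 2 `CCOc1cc(C)c(Oc2nc(C)cc(OC(CC)CC)c2C)c(C)c1` share one core and have both been run in a functional assay on the whole organism for displacement of a labelled ligand, with Rattus norvegicus as the target, at a dose of 3.2 mg/kg by the oral route; on this read-out higher numbers stand for more inhibition at the one dose given (going by the name of the read-out) and lower numbers for less inhibition. Compound 1 gives 75%. Going by the values given here, compound 2 gives 43%, the lower of the two numbers, and the one step that joins them is a number 32 percentage points lower from compound 1 to compound 2 (beyond the scatter), a change at a saturated chain carbon bound to an oxygen on an aromatic ring.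

Compound 3 `CCC(CC)Oc1cc(C)nc(Oc2c(C)cc(CO)cc2C)c1C` has not been measured. It departs from compound 2 by hydroxymethyl in place of ethoxy on an aromatic carbon. Among the compounds with values here, this exchange on an aromatic carbon of a six-membered aromatic ring of carbon only, para to a large group, has no counterpart among the measured pairs: the one step on record changes a saturated chain, not the group on this aromatic carbon, so it does not bear on the present change. In the absence of a comparable step, the expectation for compound 3 in this assay is set near the value of compound 2, with a wide range in either direction, and the expected step is a number 3 percentage points lower from compound 2 to compound 3 (within the scatter). The estimate for compound 3 is therefore 40%, between 15% and 70%.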

Compound 3, a percentage reported as inhibition, in the whole organism at one dose (the size of the read-out at that dose, not a potency): 42%
Compound 3: middle estimate off by 2 percentage points, on the low side; low and high end bracket the measured number.
By their numbers in this assay, from the lowest: compounds 3 and 2 (each within the scatter of the next); then compound 1.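

At the aromatic carbon para to a large group, the exchange of ethoxy for hydroxymethyl gives a number 1 percentage points lower from compound 2 to compound 3 (within the scatter) in this assay, whereas the exchange of methoxy for hydroxymethyl gives a number 33 percentage points lower from compound 1 to compound 3 (beyond the scatter). Compound 1, with methoxy on this carbon, therefore stands apart from both compound 2 and compound 3, so the loss on record is no longer tied to the ethoxy group alone: two different groups, one with a hydrogen-bond donor and one without, give numbers within the scatter of each other. No measured information on the cause of this pattern is available here, and the result gives no reason for the place of methoxy in the set.

Open, as far as these compounds go, is whether the high number belongs to methoxy alone, or whether a group such as an aminomethyl, a carboxylic acid, a chlorine or a longer chain such as propoxy on this aromatic carbon would also reach the level of compound 1. With a single oral dose as the only read-out, these three compounds also leave open how the numbers would change at other doses.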